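The source may report more compounds than this note shows. Statements on the series, on what has been measured and on what is new or still open speak of the compounds shown alone.

In a functional assay on HepG2 cells (Homo sapiens) for inhibition, read by MTT assay, with a stated time of 72 h (a lower number here means a stronger inhibitor, a higher number a weaker inhibitor), compound 1 `Cc1ccc(-c2nnc(SCCCN3CCN(c4nc5ccccc5o4)CC3)o2)cc1` gives 154000 nM, compound 2 `Clc1ccc(-c2nnc(SCCCN3CCN(c4nc5ccccc5o4)CC3)o2)cc1` gives 121000 nM and compound 3 `O=C(NCc1nnc(SCCCN2CCN(c3nc4ccccc4o3)CC2)o1)c1ccccc1` gives 88900 nM. Compound 2 stands level with both others. The steps that touch it are a 1.3-fold lower number from compound 1 to compound 2 (0.10 log units; within the scatter) and a 1.4-fold lower number from compound 2 to compound 3 (0.13 log units; within the scatter). Compound 4 `Clc1ccc(-c2nnc(SCCCN3CCN(c4nc5ccccc5s4)CC3)o2)cc1` carries one change on an amine nitrogen in a ring: 1,3-benzothiazol-2-yl in place of 1,3-benzoxazol-2-yl on an amine nitrogen in a ring. Among the measured compounds shown here, no measured step alters this group. All of them, including a 1.7-fold lower number from compound 1 to compound 3 (0.24 log units; within the scatter), change a group on an aromatic carbon, and none leaves the scatter. Nothing therefore points to a real shift in this assay, in either direction. The estimated step is a 1.2-fold lower number from compound 2 to compound 4 (0.08 log units; within the scatter), which is expected to stay within the scatter. For compound 4 the expected value is 100000 nM, with an estimated range from 45000 nM to 220000 nM.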

Compound 4, half-maximal inhibitory concentration: 87700 nM
For compound 4 the middle estimate is 1.1-fold (0.06 log units) above the measured one; measured number inside the range.
By their numbers in this assay, from the lowest: compounds 4, 3, 2 and 1 (each within the scatter of the next).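

In this assay, among the compounds shown here, the first measured change on the amine nitrogen in the ring, 1,3-benzothiazol-2-yl in place of 1,3-benzoxazol-2-yl, gives a 1.4-fold lower number from compound 2 to compound 4 (0.14 log units; within the scatter). This position therefore tolerates the exchange of oxygen for sulfur with no real shift, just as the earlier changes on an aromatic carbon produced none. Nothing available explains this result.

This single exchange does not show whether a group of another kind on this nitrogen, such as acetyl or pyridin-2-yl, would leave the scatter. On these data alone, whether the same exchange stays level with another group in place of 4-chlorophenyl also remains open.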